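Aryl swap on the spirocyclic glucagon antagonist core

The source may report more compounds than this note shows. Statements on the series, on what has been measured and on what is new or still open speak of the compounds shown alone.

Among the measured compounds shown here, compound 1 `C[C@H](c1ccc(C(=O)NCCC(=O)O)cc1)N1C(=O)C(c2cccc(C3CC3)c2)=N[C@]12CC[C@@H](C(C)(C)C)CC2` is one of three compounds measured in a functional assay on CHO cells for antagonist activity at Glucagon receptor (Homo sapiens), read by cAMP accumulation, with stated times of 30 min and 45 min (on this read-out higher numbers stand for weaker inhibition and lower numbers for stronger inhibition), where compound 1 gives 340 nM. Compound 3 `CC(C)(C)CC[C@H](c1ccc(C(=O)NCCCC(=O)O)cc1)N1C(=O)C(c2cc(Cl)cc(Cl)c2)=N[C@]12CC[C@@H](C(C)(C)C)CC2` gives 350 nM in this assay, a number within the scatter of compound 1. Compound 2 `CCCCC[C@H](c1ccc(C(=O)NCc2nn[nH]n2)cc1)N1C(=O)C(c2cc(Cl)cc(Cl)c2)=N[C@]12CC[C@@H](C(C)(C)C)CC2` gives 130 nM, a lower number than compound 1 that lies beyond the scatter. Compound 4 `C[C@H](c1ccc(C(=O)NCCC(=O)O)cc1)N1C(=O)C(c2cccc(Cl)c2F)=N[C@]12CC[C@@H](C(C)(C)C)CC2` differs from compound 1 only in the aryl group, with 3-chloro-2-fluorophenyl in place of 3-cyclopropylphenyl on a carbon with a double bond to nitrogen. For the measured compounds named here, no measured pair in this set isolates such a change, so no comparable step is known. The change from compound 1 to compound 4 is expected to produce a step of about a 1.1-fold lower number from compound 1 to compound 4 (0.05 log units; within the scatter), not beyond the scatter in either direction. Compound 4 is therefore estimated at 300 nM, with a range from 120 nM to 800 nM.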

Compound 4, half-maximal inhibitory concentration: 630 nM
Estimate against measurement, compound 4: 2.1-fold (0.32 log units) below, and the stated range covers the measured number.
By their numbers in this assay, from the lowest: compound 2; then compounds 1, 3 and 4 (each within the scatter of the next).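

In this assay, among the compounds shown here, the step of a 1.9-fold higher number from compound 1 to compound 4 (0.27 log units; within the scatter) gives the first comparison at this position on the shared core, where 3-chloro-2-fluorophenyl replaces 3-cyclopropylphenyl. The position on the carbon with a double bond to nitrogen thus carries either group without a change beyond the scatter. Nothing available here accounts for the size of this step. Still open, on these data alone, is how a phenyl group bearing a nitrile or an amine would read at this position. Also open, as far as these compounds go, is whether the same exchange gives a similar step with the longer chains and tetrazole of compound 2 or compound 3.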